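This account rests on a few compounds, and the source may have more. Where it says the series, first, only, none or still open, it means among the compounds named here.

Measured so far:
Compound 1 `COc1cc(NC(C)CCCNC(=O)NNC(=O)Nc2cccc(F)c2)c2ncccc2c1` — > 250000 nM
Compound 2 `COc1cc(NC(C)CCCNC(=O)Nc2ccc(O)cc2)c2ncccc2c1` — 70000 nM
Compound 3 `COc1cc(NC(C)CCCNC(=O)NNC(=O)Nc2cccc(Cl)c2)c2ncccc2c1` — 44000 nM

All three compounds share the same core and were tested in a functional assay on HeLa cells (Homo sapiens) for inhibition, read by MTT assay, with a stated time of 72 h; a lower number here means a stronger inhibitor, a higher number a weaker inhibitor. Compound 1 gives only a limit of the assay, (the limit of > 250000 nM in this assay, at which 1 of the 3 values shown sits), so its true value is not known as a number. Compound 2 and compound 3 give numbers, and the two sit within the usual scatter of each other, as the step of a 1.6-fold lower number from compound 2 to compound 3 (0.20 log units; within the scatter) shows.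

The unmeasured compound 4 `COc1cc(NC(C)CCCNC(=O)Nc2ccc(Br)cc2)c2ncccc2c1` differs from compound 1 in one place: 4-bromophenyl in place of ((3-fluorophenyl)carbamoyl)amino on an amide-type nitrogen.

For the measured compounds named here, two measured steps bear on this change. Replacing the same group on compound 1 by an aryl group in compound 2 gave an at least 3.5-fold lower number from compound 1 to compound 2 (0.55 log units; beyond the scatter), and the change of halogen in compound 3 gave an at least 5.6-fold lower number from compound 1 to compound 3 (0.75 log units; beyond the scatter). Both steps start from a limit, so their real size is only a floor, and both point downward. Compound 4 keeps an aryl group directly on the amide-type nitrogen, as in compound 2, but carries a bromine instead of a hydroxyl, so it is expected to land near compound 2 or somewhat lower.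

For compound 4 the estimate is 40000 nM, with a range of 10000 nM to 150000 nM, meaning a step of an at least 6.2-fold lower number from compound 1 to compound 4 (0.79 log units; beyond the scatter).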

Compound 4, half-maximal inhibitory concentration: 20000 nM
Compound 4: the middle estimate sits 2.0-fold (0.30 log units) above what was measured; low and high end bracket the measured number.
By their numbers in this assay, from the lowest: compound 4; then compounds 3 and 2 (each within the scatter of the next). At a limit, above all of these: compound 1.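

In this assay, placing 4-bromophenyl on the amide-type nitrogen of compound 1 gives an at least 12-fold lower number from compound 1 to compound 4 (1.09 log units; beyond the scatter), but this is only a floor for the true size of the step, and compound 1 itself has only a limit, not a number: the limit of > 250000 nM in this assay, at which 1 of the 4 values shown sits. The new result also separates two groups on this nitrogen, where compounds 2 and 3 could not be told apart: 4-bromophenyl in place of ((3-chlorophenyl)carbamoyl)amino gives a 2.2-fold lower number from compound 3 to compound 4 (0.34 log units; beyond the scatter). The group carried on the phenyl ring matters as well, as bromo in place of hydroxy gives a 3.5-fold lower number from compound 2 to compound 4 (0.54 log units; beyond the scatter), a step beyond the usual scatter between two compounds that both have a phenyl ring directly on that nitrogen.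

The compounds shown leave open whether a chloro, a methoxy or an amine in place of the bromine would give a lower or a higher number. They also leave open whether a longer chain in place of the one carrying the amide-type nitrogen would shift these values.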